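Growing the urea substituent in a sulfonamide-oxadiazole series

A few compounds are considered here, and "the series" means these few. Any claim that something is new, unique, unknown or untested is made for them only; others in the source may bear on it.

Among the measured compounds shown here, compound 2 `CCNC(=O)Nc1ccc(S(=O)(=O)Nc2cccc(-c3nc(-c4ccc(NC(=O)c5cccnc5)cc4Cl)no3)c2)cc1` gives the highest of the two numbers so far in a functional assay on MDA-MB-231 cells (Homo sapiens) for antiproliferative activity, read by MTT assay, with a stated time of 72 h (a lower number here means a stronger inhibitor, a higher number a weaker inhibitor), at 3100 nM; its nearest neighbour, compound 1 `CNC(=O)Nc1ccc(S(=O)(=O)Nc2cccc(-c3nc(-c4ccc(NC(=O)c5cccnc5)cc4Cl)no3)c2)cc1`, gives 1300 nM. For the measured compounds named here, that pair defines the only step in hand, a 2.4-fold higher number from compound 1 to compound 2 (0.38 log units; beyond the scatter). Compound 3 `O=C(Nc1ccc(S(=O)(=O)Nc2cccc(-c3nc(-c4ccc(NC(=O)c5cccnc5)cc4Cl)no3)c2)cc1)NC1CCCC1` carries the change (cyclopentyl in place of ethyl on an amide-type nitrogen). Going by the values given here, the one step that bears on it went toward weaker inhibition, so a further modest weakening is expected, a 1.6-fold higher number from compound 2 to compound 3 (0.21 log units; within the scatter), though a larger group is not the same change. Compound 3 is thus estimated at 5000 nM, within 1500 nM to 15000 nM.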

Compound 3, half-maximal inhibitory concentration: > 10000 nM
Compound 3 was reported as a limit (the forecaster's own chance of this, stated with the estimate: 10%); middle value at least 2.0-fold (0.30 log units) from the limit.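

In this assay compound 3 stands only as a limit, > 10000 nM. On the amide-type nitrogen, cyclopentyl in place of ethyl gives an at least 3.2-fold higher number from compound 2 to compound 3 (0.50 log units; beyond the scatter), and cyclopentyl in place of methyl gives an at least 7.6-fold higher number from compound 1 to compound 3 (0.88 log units; beyond the scatter). The trend toward weaker inhibition from methyl to ethyl thus extends to a five-membered ring of carbon, with no compound shown against it, though its full size cannot be read: the limit of > 10000 nM in this assay, at which 1 of the 3 values shown sits.

Going by these compounds, what hydrogen on this nitrogen would give remains open. So does whether a chain ending in an amine or a hydroxyl would follow the same trend.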